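Lengthening the chain on the aromatic nitrogen

The source may hold more compounds than are shown below. What is called first, only, known or untested is meant among the compounds shown, and "the series" means these compounds.

Compounds measured so far in a functional assay on KB cells (Homo sapiens) for inhibition, with a stated time of 72 h; a higher number here means a weaker inhibitor, a lower number a stronger inhibitor
- compound 1 `COc1cc(C(=O)c2ccc3[nH]ccc3c2)cc(OC)c1OC` gives 104 nM
- compound 2 `COc1cc(C(=O)c2ccc3c(ccn3C)c2)cc(OC)c1OC` gives 13.6 nM
- compound 3 `CCn1ccc2cc(C(=O)c3cc(OC)c(OC)c(OC)c3)ccc21` gives 36 nM

Compound 3 stands second highest of the three numbers, with a 2.6-fold higher number from compound 2 to compound 3 (0.42 log units; beyond the scatter) and, on the other side, a 2.9-fold lower number from compound 1 to compound 3 (0.46 log units; beyond the scatter). The next compound is compound 4 `CCCn1ccc2cc(C(=O)c3cc(OC)c(OC)c(OC)c3)ccc21`, not yet measured. The change is methyl in place of hydrogen on a saturated chain carbon, two bonds along the chain from an aromatic nitrogen, which takes ethyl to propyl.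

For the measured compounds named here, the closest precedent is that same step a 2.6-fold higher number from compound 2 to compound 3 (0.42 log units; beyond the scatter), where methyl went to ethyl one carbon nearer the aromatic nitrogen. The other two steps, a 7.6-fold lower number from compound 1 to compound 2 (0.88 log units; beyond the scatter) and a 2.9-fold lower number from compound 1 to compound 3 (0.46 log units; beyond the scatter), show both alkyl compounds lower than the unsubstituted compound 1, but they say nothing about a longer chain. Going by the values given here, a single chain-lengthening step is a thin basis, and no propyl example exists in this set. A further rise of similar or somewhat smaller size is therefore expected in this assay, and a result within the scatter would not be surprising. The expected step is a 1.9-fold higher number from compound 3 to compound 4 (0.29 log units; within the scatter). Compound 4 is estimated at 70 nM, with an expected range from 32 nM to 160 nM.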

Compound 4, half-maximal inhibitory concentration: 1900 nM
The estimate for compound 4 lay 27-fold (1.43 log units) below the measured number, and the stated range ends below it.
By their numbers in this assay, from the lowest: compound 2; then compound 3; then compound 1; then compound 4.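

In this assay the chain on the aromatic nitrogen does not change the number gradually: a 53-fold higher number from compound 3 to compound 4 (1.72 log units; beyond the scatter) is far larger than the earlier methyl to ethyl step a 2.6-fold higher number from compound 2 to compound 3 (0.42 log units; beyond the scatter) and shows that this position can lose most of its activity through one added methyl, two bonds along the chain from the aromatic nitrogen. Propyl also reverses what the methyl and ethyl compounds suggested, since it ends up on the far side of the unsubstituted compound with an 18-fold higher number from compound 1 to compound 4 (1.26 log units; beyond the scatter) and the whole span from methyl to propyl is a 140-fold higher number from compound 2 to compound 4 (2.15 log units; beyond the scatter). Across compound 2, compound 3 and compound 4 the number rises with each added carbon, while compound 1, with hydrogen on the nitrogen, goes against that order, and no measurement shown here accounts for the sharp jump at propyl.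

Still open, going by these compounds, is whether a butyl or longer chain climbs further or levels off. Also open, on these data alone, is whether a branched isopropyl group, or a short chain ending in a hydroxyl or an amine, behaves like ethyl or like propyl at this nitrogen.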